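Ortho Substitution on the Aryl Group: Compound 3

A few compounds are considered here, and "the series" means these few. Any claim that something is new, unique, unknown or untested is made for them only; others in the source may bear on it.

Among the compounds with values here, compound 2 `CCc1ccccc1C1C(=O)N(C)c2cnc(Nc3ccc(S(N)(=O)=O)cc3)nc2N1C` stands lowest of the two numbers so far in an assay on Sf9 cells for inhibition of serine/threonine-protein kinase 4 (Homo sapiens), read by luminescence and ADP-Glo, with a stated time of 1 h, in the presence of a further agent that is not named here (on this read-out higher numbers stand for weaker inhibition and lower numbers for stronger inhibition), giving 51 nM; compound 1 `CN1C(=O)C(c2ccc(F)cc2)N(C)c2nc(Nc3ccc(S(N)(=O)=O)cc3)ncc21` gives 1770 nM. Within the data shown here, the one step in the set, a 35-fold lower number from compound 1 to compound 2 (1.54 log units; beyond the scatter), bears on the new change, as it also altered this aryl group. Compound 3 `CN1C(=O)C(c2c(F)cccc2F)N(C)c2nc(Nc3ccc(S(N)(=O)=O)cc3)ncc21` carries 2,6-difluorophenyl in place of 2-ethylphenyl on a saturated ring carbon. Among the measured compounds shown here, since no measured step swaps an ethyl for fluorine here, the outcome is uncertain; a rise of intermediate size, a 5.9-fold higher number from compound 2 to compound 3 (0.77 log units; beyond the scatter), is expected. Compound 3 is estimated at 300 nM, within 60 nM to 1500 nM.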

Compound 3, half-maximal inhibitory concentration: 42 nM
The estimate for compound 3 lay 7.1-fold (0.85 log units) above the measured number; measured number below the stated range.
By their numbers in this assay, from the lowest: compounds 3 and 2 (each within the scatter of the next); then compound 1.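

In this assay the 2,6-difluorophenyl and 2-ethylphenyl groups on this saturated ring carbon cannot be told apart, with a 1.2-fold lower number from compound 2 to compound 3 (0.08 log units; within the scatter), even though one carries two fluorines and the other an ethyl group. Compound 1, with its 4-fluorophenyl group, stays clearly separate, as a 42-fold lower number from compound 1 to compound 3 (1.62 log units; beyond the scatter) shows. Nothing available here explains these results.

Still open, going by these compounds, is how a chlorophenyl or methoxyphenyl group would read at this carbon. A pyridine ring in place of the phenyl ring is equally untested among the compounds shown.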